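This account rests on a few compounds, and the source may have more. Where it says the series, first, only, none or still open, it means among the compounds named here.

In a functional assay on cells (Renal cancer cell line, Homo sapiens) for cytotoxicity, read by sulforhodamine B assay, with a stated time of 48 h (a lower number here means a stronger inhibitor of growth, a higher number a weaker inhibitor of growth), compound 2 (`COc1ccc2c(c1)/C(=C\c1c(OC)nc3sc(C)cn13)C(=O)N2`) gives 61800 nM and sits within the scatter of compound 1 (`COc1cc2c(cc1C)NC(=O)/C2=C/c1c(OC)nc2sc(C)cn12`) at 58900 nM with no other number yet in hand. Compound 3 (`COc1nc2sc(C)cn2c1/C=C1/C(=O)Nc2ccccc21`) differs from compound 2 by hydrogen in place of methoxy on an aromatic carbon in the form of hydrogen in place of methoxy on an aromatic carbon. Among the compounds with values here, the only measured step (a 1.0-fold higher number from compound 1 to compound 2 (0.02 log units; within the scatter)) is hydrogen in place of methyl on an aromatic carbon. It involves a different group and stays within the scatter, so no step beyond the scatter is expected in this assay here. Compound 3 is estimated at 60000 nM (range 28000 nM to 100000 nM). The expected change is a 1.0-fold lower number from compound 2 to compound 3 (0.01 log units; within the scatter).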

Compound 3, concentration for total growth inhibition: 67600 nM
Compound 3: the middle estimate sits 1.1-fold (0.05 log units) below what was measured, and the stated range covers the measured number.
By their numbers in this assay, from the lowest: compounds 1, 2 and 3 (each within the scatter of the next).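

In this assay, hydrogen in place of methoxy on the six-membered aromatic ring of carbon only gives a 1.1-fold higher number from compound 2 to compound 3 (0.04 log units; within the scatter), so at this position the methoxy group and hydrogen cannot be told apart. Within the data shown here, the earlier step covered only the methyl group, so this is the first reading for the methoxy group on this ring. Nothing available bears on the reason for this result. Still open, going by these compounds, is whether an amine, a carboxylic acid or a chlorine atom at this position would give a step beyond the scatter.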